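From 3-methylphenyl to 4-methylphenyl in compound 3

A few compounds are considered here, and "the series" means these few. Any claim that something is new, unique, unknown or untested is made for them only; others in the source may bear on it.

In a functional assay on MCF7 cells (Homo sapiens) for inhibition, read by MTT assay, with a stated time of 72 h (a higher number here means a weaker inhibitor, a lower number a stronger inhibitor), compound 1 `COc1cc2c(Oc3ccc(NC(=O)c4nn(-c5cccc(C(F)(F)F)c5)cc(C)c4=O)cc3)ccnc2cc1OCCCCCCC(=O)NO` gives 750 nM, while compound 2 `COc1cc2c(Oc3ccc(NC(=O)c4nn(-c5cccc(C)c5)cc(C)c4=O)cc3)ccnc2cc1OCCCCCCC(=O)NO` gives 1680 nM, the higher of the two numbers. For the measured compounds named here, the only measured step, a 2.2-fold higher number from compound 1 to compound 2 (0.35 log units; beyond the scatter), is modest and swaps trifluoromethyl for methyl on an aromatic carbon. Compound 3 `COc1cc2c(Oc3ccc(NC(=O)c4nn(-c5ccc(C)cc5)cc(C)c4=O)cc3)ccnc2cc1OCCCCCCC(=O)NO` differs otherwise: 4-methylphenyl in place of 3-methylphenyl on an aromatic nitrogen. Going by the values given here, no measured step shows such a move, so no step beyond the scatter is expected in this assay. The estimate means a 1.1-fold lower number from compound 2 to compound 3 (0.05 log units; within the scatter), an expected step of small size. For compound 3 the estimated value is 1500 nM, with an expected range from 650 nM to 3500 nM.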

Compound 3, half-maximal inhibitory concentration: 2560 nM
Beside the measured number, compound 3's estimate is 1.7-fold (0.23 log units) below it; the range from low to high includes it.
By their numbers in this assay, from the lowest: compound 1; then compounds 2 and 3 (each within the scatter of the next).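

In this assay, setting 4-methylphenyl in place of 3-methylphenyl on the aromatic nitrogen gives a 1.5-fold higher number from compound 2 to compound 3 (0.18 log units; within the scatter), so these two methyl placements cannot be told apart. Compound 1 with its 3-(trifluoromethyl)phenyl group stays ahead of this methyl isomer too, with a 3.4-fold higher number from compound 1 to compound 3 (0.53 log units; beyond the scatter). No measurement available here accounts for these differences.

Still open, as far as these compounds go, is whether 4-(trifluoromethyl)phenyl on the same nitrogen would give a number like that of compound 1 or one like those of the methyl pair. From the compounds shown here alone, how an unsubstituted phenyl or a 3-chlorophenyl group would compare also remains open.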